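A few compounds are considered here, and "the series" means these few. Any claim that something is new, unique, unknown or untested is made for them only; others in the source may bear on it.

In a functional assay on the whole organism (strain Wistar) for inhibition, with Rattus norvegicus as the target, read by paw edema, with stated times of 60 min and 6 h, at a dose of 100 mg/kg by the oral route (on this read-out lower numbers stand for less inhibition and higher numbers for more inhibition at the one dose given (going by the name of the read-out)), three compounds have been measured: compound 1 `CNC(=O)CC1CCc2cc(OC)c(OC)cc21` with 24.1%, compound 2 `CCNC(=O)CC1CCc2cc(OC)c(OC)cc21` with 20.4%, and compound 3 `COc1cc2c(cc1OC)C(CC(=O)NC(C)(C)C)CC2` with 31.5%.

Compound 2 gives the lowest of the three numbers. Its nearest neighbour is compound 1: the step of a number 3.7 percentage points lower from compound 1 to compound 2 (within the scatter) lies within the scatter, so the two cannot be ordered. The step of a number 11.1 percentage points higher from compound 2 to compound 3 (beyond the scatter) is beyond the scatter, though only modest, and the step of a number 7.4 percentage points higher from compound 1 to compound 3 (within the scatter) stays within it.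

Compound 4 `COc1cc2c(cc1OC)C(CC(=O)NCc1ccccc1)CC2` is the unmeasured compound. It differs from compound 2 by phenyl in place of methyl on a saturated chain carbon bound to an amide-type nitrogen.

Going by the values given here, two measured steps bear on this change. The step of a number 3.7 percentage points lower from compound 1 to compound 2 (within the scatter) shows that adding a methyl on the saturated chain carbon bound to the amide-type nitrogen left the number within the scatter. The steps of a number 11.1 percentage points higher from compound 2 to compound 3 (beyond the scatter) and a number 7.4 percentage points higher from compound 1 to compound 3 (within the scatter) show that a bulkier group on the amide-type nitrogen moved the number upward by a small amount at most. Among the compounds with values here, a phenyl entering on the chain carbon is a larger change than either, but nothing among the measured compounds points to a direction beyond the scatter. The step of a number 5.6 percentage points higher from compound 2 to compound 4 (within the scatter) is therefore expected to be small and positive, and compound 4 is estimated at 26%, between 14% and 38%.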

Compound 4, a percentage reported as inhibition, in the whole organism at one dose (the size of the read-out at that dose, not a potency): 30.6%
The estimate for compound 4 lay 4.6 percentage points below the measured number, within the range that was stated.
By their numbers in this assay, from the lowest: compounds 2, 1, 4 and 3 (each within the scatter of the next, the first and the last beyond it).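

Going by these compounds alone, the phenyl in place of methyl on a saturated chain carbon bound to an amide-type nitrogen gives a number 10.2 percentage points higher from compound 2 to compound 4 (beyond the scatter) in this assay, a modest change but one beyond the scatter, whereas the only earlier change at this carbon, methyl in place of hydrogen, gave a number 3.7 percentage points lower from compound 1 to compound 2 (within the scatter). The same position compared with hydrogen reads a number 6.5 percentage points higher from compound 1 to compound 4 (within the scatter), so the change shows up only against the ethyl of compound 2, and the benzyl group cannot be separated from the unsubstituted methyl amide of compound 1. On the amide-type nitrogen, benzyl in place of tert-butyl gives a number 0.9 percentage points lower from compound 3 to compound 4 (within the scatter), so these two groups cannot be ordered, and no measurement offered here explains any of these numbers.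

The compounds shown leave open whether a longer chain between the amide-type nitrogen and the phenyl ring, or a carboxylic acid or an amine on that ring, would move the number further from that of compound 2. On these data alone, each compound is also read at a single dose, so how their potencies compare remains open.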